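Swapping 3-Methylphenyl for 4-Fluorophenyl on the Shared Core

A few compounds are considered here, and "the series" means these few. Any claim that something is new, unique, unknown or untested is made for them only; others in the source may bear on it.

Compound 2 `COc1cc(-n2cnc3ccc(-c4cccc(C)c4)cc32)cc(OC)c1OC` gives 360 nM in a functional assay on MCF7 cells (Homo sapiens) for antiproliferative activity, read by MTT assay, with a stated time of 72 h (on this read-out lower numbers stand for stronger inhibition and higher numbers for weaker inhibition), the lower of the two numbers shown, though compound 1 `COc1ccc(-c2ccc3ncn(-c4cc(OC)c(OC)c(OC)c4)c3c2)cc1F` at 520 nM is separated from it only by the within-scatter step a 1.4-fold lower number from compound 1 to compound 2 (0.16 log units; within the scatter). Compound 3 `COc1cc(-n2cnc3ccc(-c4ccc(F)cc4)cc32)cc(OC)c1OC` differs from compound 2 by 4-fluorophenyl in place of 3-methylphenyl on an aromatic carbon. Within the data shown here, the single measured step that bears on this position was small, so no shift beyond the scatter is expected in this assay. Compound 3 is therefore expected at 400 nM, within 200 nM to 800 nM, which implies an expected step of a 1.1-fold higher number from compound 2 to compound 3 (0.05 log units; within the scatter).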

Compound 3, half-maximal inhibitory concentration: 1770 nM
Compound 3: middle estimate off by 4.4-fold (0.65 log units), on the low side; the whole stated range lies below it.
By their numbers in this assay, from the lowest: compounds 2 and 1 (each within the scatter of the next); then compound 3.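

The position is not indifferent to the choice of aryl group in this assay because here a 4.9-fold higher number from compound 2 to compound 3 (0.69 log units; beyond the scatter) and this step lies beyond the scatter, which the earlier pair did not show. The 4-fluorophenyl group also separates from the 3-fluoro-4-methoxyphenyl group, since a 3.4-fold higher number from compound 1 to compound 3 (0.53 log units; beyond the scatter) and that step too lies beyond the scatter. Nothing measured here accounts for either step.

The compounds shown leave open whether the change follows the fluorine or where the substituent sits on the phenyl ring. They also leave open how an amine or a carboxylic acid on that ring would read.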